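Taking the 4-nitrophenyl off compound 3

The compounds below may be only part of what the source reports. "The series", "measured", "known", "first", "only" and "open" are said of these compounds alone.

Measured in a functional assay, read by spectrophotometry, with a stated time of 5 min; a lower number here means a stronger inhibitor, a higher number a weaker inhibitor:
Compound 1 `O=c1cc(/C=N\c2ccc(O)cc2)c2ccc(OCc3ccccc3)cc2o1`: 525000 nM
Compound 2 `N/N=C\c1cc(=O)oc2cc(OCc3ccccc3)cc(OCc3ccccc3)c12`: 36500 nM
Compound 3 `O=c1cc(/C=N\Nc2ccc([N+](=O)[O-])cc2)c2ccc(OCc3ccccc3)cc2o1`: > 2000000 nM, a limit and not a number

Compound 3 has no number, only (the limit of > 2000000 nM in this assay, at which 1 of the 3 values shown sits). Compound 4 `N/N=C\c1cc(=O)oc2cc(OCc3ccccc3)ccc12` differs from it as follows: hydrogen in place of 4-nitrophenyl on an amine nitrogen. In words, this is hydrogen in place of 4-nitrophenyl on an amine nitrogen. Among the measured compounds shown here, one measured step bears on this: an at least 3.8-fold higher number from compound 1 to compound 3 (0.58 log units; beyond the scatter), which leads to the (4-nitrophenyl)amino group that compound 4 gives up. Compound 2 carries the same amino group as compound 4, and compound 2 gives 36500 nM. In this assay a clear move to a lower number is therefore expected, an at least 25-fold lower number from compound 3 to compound 4 (1.39 log units; beyond the scatter). For compound 4 the estimated value is 80000 nM, with an expected range from 15000 nM to 400000 nM.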

Compound 4, half-maximal inhibitory concentration: 131000 nM
Estimate against measurement, compound 4: 1.6-fold (0.21 log units) below; the measured number falls inside the stated range.
By their numbers in this assay, from the lowest: compound 2; then compound 4; then compound 1. At a limit, above all of these: compound 3.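

In this assay, among the compounds shown here, hydrogen in place of 4-nitrophenyl on an amine nitrogen gives an at least 15-fold lower number from compound 3 to compound 4 (1.18 log units; beyond the scatter), the first step to show that the plain amino group gives a measurable number at this position. Compound 3 stands at a limit, so this step is a bound and not an exact size: the limit of > 2000000 nM in this assay, at which 1 of the 4 values shown sits. Amino in place of 4-hydroxyphenyl on a double-bonded nitrogen gives a 4.0-fold lower number from compound 1 to compound 4 (0.60 log units; beyond the scatter), while hydrogen in place of benzyloxy on an aromatic carbon gives a 3.6-fold higher number from compound 2 to compound 4 (0.55 log units; beyond the scatter).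

From the compounds shown here alone, it remains open whether a methyl or an unsubstituted phenyl on that amine nitrogen would lie nearer compound 4 or compound 3. Going by these compounds, it is also open whether a methoxy in place of that benzyloxy would keep the lower number of compound 2.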